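This account rests on a few compounds, and the source may have more. Where it says the series, first, only, none or still open, it means among the compounds named here.

Compound 1 `COc1ccc(C2N=C(SCc3ccccc3)NC(C)=C2C(=O)Nc2ccc(F)cc2)cc1OC`, compound 2 `COc1ccc(C2N=C(SCc3ccc(Cl)cc3)NC(C)=C2C(=O)Nc2ccc(F)cc2)cc1OC` and compound 3 `COc1ccc(C2N=C(SCc3ccccc3)NC(C)=C2C(=O)Nc2ccc(Br)cc2)cc1` were tested in a functional assay on the whole organism (artery, strain albino) with Rattus norvegicus as the target, with a stated time of 30 min, at a dose of 10 mg/kg by the oral route; a higher number here means more inhibition at the dose given (going by the name of the read-out), a lower number less inhibition. In this assay compound 1 gives 3.6%, compound 2 gives 5.7% and compound 3 gives 2.6%. Compound 2 differs from compound 1 by chloro in place of hydrogen on an aromatic carbon, and this step a number 2.1 percentage points higher from compound 1 to compound 2 (within the scatter). The difference between the cores of compound 1 and compound 3 is not broken down here. Compound 4 `COc1ccc(C2N=C(SCc3ccccc3Cl)NC(C)=C2C(=O)Nc2ccc(Br)cc2)cc1` is not yet measured; it differs from compound 3 by chloro in place of hydrogen on an aromatic carbon. This is the same kind of change as from compound 1 to compound 2, but here the chloro sits ortho to a large group, whereas there it sat para to a large group. The expectation for compound 4 rests on compound 3 with 2.6% and on the small earlier step of a number 2.1 percentage points higher from compound 1 to compound 2 (within the scatter). Compound 4 is expected to give about 4.5%, likely between -4% and 13%. The expected step is a number 1.9 percentage points higher from compound 3 to compound 4 (within the scatter).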

Compound 4, a percentage reported as inhibition, in the whole organism at one dose (the size of the read-out at that dose, not a potency): 4.6%
The estimate for compound 4 lay 0.1 percentage points below the measured number; measured number inside the range.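

The chloro change gives a number 2 percentage points higher from compound 3 to compound 4 (within the scatter) in this assay. Set beside the earlier step on the other core, the two agree: the same change on two cores in this assay, a number 2.1 percentage points higher (within the scatter) from compound 1 to compound 2 and a number 2 percentage points higher (within the scatter) from compound 3 to compound 4, 0.1 percentage points apart, within the scatter of two such steps. This shows that the change behaves alike on the two cores tested, leaving the inhibition practically where it was; it does not show that chloro has any real effect, as each step lies within the scatter, and two pairs cannot speak for other cores.

All the compounds shown carry a benzylsulfanyl group, plain or with a chloro on its ring. As far as these compounds go, whether an amine or a carboxylic acid on that ring, or a longer chain in place of the benzyl, would move the inhibition beyond the scatter stays open.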